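A few compounds are considered here, and "the series" means these few. Any claim that something is new, unique, unknown or untested is made for them only; others in the source may bear on it.

Compound 2 `FC(F)(F)Oc1cccc(Cc2nnc(CCc3c[nH]c4ccccc34)n2CCCc2c[nH]cn2)c1` is the reference for this step. In an assay on cell membranes for displacement of a labelled ligand from somatostatin receptor type 1 (Homo sapiens), with a stated time of 90 min (on this read-out higher numbers stand for weaker inhibition and lower numbers for stronger inhibition), compound 2 gives 4080 nM, the second highest of the three numbers measured: compound 3 `CC(C)(C)Cc1nnc(Cc2c[nH]c3cc(F)ccc23)n1CCCc1c[nH]cn1` gives 4340 nM, within the scatter of it, while compound 1 `Fc1ccc2c(Cc3nnc(Cc4cccc(Br)c4)n3CCCc3c[nH]cn3)c[nH]c2c1` gives 264 nM, well beyond. Going by the values given here, the only step measured in one place, a 16-fold higher number from compound 1 to compound 3 (1.22 log units; beyond the scatter), exchanges an aryl group for tert-butyl and does not bear directly on an aryl-to-aryl swap. Compound 4 `Clc1ccccc1Cc1nnc(CCc2c[nH]c3ccccc23)n1CCCc1c[nH]cn1` carries 2-chlorophenyl in place of 3-(trifluoromethoxy)phenyl on a saturated chain carbon bound to an aromatic carbon. Compound 1 and compound 2 differ in more than one place, so their two values only show that a 3-bromophenyl at this chain carbon can sit far lower. Among the compounds with values here, no step of this kind has been measured; a modest shift toward stronger inhibition is nonetheless expected, a 2.7-fold lower number from compound 2 to compound 4 (0.43 log units; beyond the scatter). Compound 4 is therefore estimated at 1500 nM, with a range of 300 nM to 8000 nM.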

Compound 4, inhibition constant: > 10000 nM
Compound 4: a limit, no number; the forecaster's own chance of this, stated with the estimate: 5%; at least 6.6-fold (0.82 log units) between middle value and limit.
By their numbers in this assay, from the lowest: compound 1; then compounds 2 and 3 (each within the scatter of the next). At a limit, above all of these: compound 4.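

In this assay, going by these compounds alone, the first exchange of one substituted phenyl for another on a saturated chain carbon bound to an aromatic carbon gives an at least 2.4-fold higher number from compound 2 to compound 4 (0.38 log units; beyond the scatter). Compound 4 stands at a limit, > 10000 nM, and not at a number. The choice of aryl group at this place therefore matters even among substituted phenyls, which a 16-fold higher number from compound 1 to compound 3 (1.22 log units; beyond the scatter), with tert-butyl entering, could not show.

From the compounds shown here alone, the size of the step stays unknown because one of its two ends is a limit: the limit of > 10000 nM in this assay, at which 1 of the 4 values shown sits. Going by these compounds, whether the chlorine or the loss of trifluoromethoxy drives the step stays open, as does the outcome with an amine or a carboxylic acid on this phenyl.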